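The source may hold more compounds than are shown below. What is called first, only, known or untested is meant among the compounds shown, and "the series" means these compounds.

Compound 1 `CCOC(=O)C1=C(C)N/C(=C/c2cc(C)n(-c3ccc(Br)cc3)c2C)C1=O` gives 62 mL.min-1.g-1 in an ADME assay on microsomes from liver (Mus musculus) for metabolic stability, read by LC-MS, tested at 1 uM (on this read-out higher numbers stand for fast clearance and lower numbers for slow clearance), and stands second highest of the three numbers recorded. Compound 2 `CCOC(=O)C1=C(C)N/C(=C/c2cc(C)n(-c3ccc(SC(F)(F)F)cc3)c2C)C1=O` gives 76 mL.min-1.g-1, and compound 3 `CCOC(=O)C1=C(C)N/C(=C/c2cc(C)n(-c3ccc(S(=O)(=O)C(F)(F)F)cc3)c2C)C1=O` gives 58 mL.min-1.g-1. The steps of a 1.2-fold higher number from compound 1 to compound 2 (0.09 log units; within the scatter) and a 1.1-fold lower number from compound 1 to compound 3 (0.03 log units; within the scatter) both lie within the scatter, as does a 1.3-fold lower number from compound 2 to compound 3 (0.12 log units; within the scatter). Compound 4 `CCOC(=O)C1=C(C)N/C(=C/c2cc(C)n(-c3ccncc3)c2C)C1=O` differs from compound 1 by pyridin-4-yl in place of 4-bromophenyl on an aromatic nitrogen. For the measured compounds named here, no measured step exchanges the aromatic ring itself; the three known steps only vary the group carried on the phenyl, and each stays within the scatter. On that basis compound 4 is expected to show a 1.1-fold lower number from compound 1 to compound 4 (0.05 log units; within the scatter), with no direction beyond the scatter foreseen. Compound 4 is therefore estimated at 55 mL.min-1.g-1, with a range from 28 mL.min-1.g-1 to 110 mL.min-1.g-1.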

Compound 4, intrinsic clearance in microsomes: 61 mL.min-1.g-1
For compound 4 the middle estimate is 1.1-fold (0.04 log units) below the measured one; the range from low to high includes it.
By their numbers in this assay, from the lowest: compounds 3, 4, 1 and 2 (each within the scatter of the next).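

Exchanging the whole ring on the aromatic nitrogen, rather than the group it carries, gives a 1.0-fold lower number from compound 1 to compound 4 (0.01 log units; within the scatter) in this assay and so stays within the scatter, as the steps on the phenyl group did. At this position, then, pyridin-4-yl with its ring nitrogen and hydrogen-bond acceptor reads the same as 4-bromophenyl on this clearance read-out. Nothing at hand accounts for this result. The compounds shown leave open whether an amine or a carboxylic acid on this ring, or a piperidine in its place, would move the number beyond the scatter.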